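Amide variation on the shared core: tertiary amide of compound 4

A few compounds are considered here, and "the series" means these few. Any claim that something is new, unique, unknown or untested is made for them only; others in the source may bear on it.

Three compounds of the series have numbers in an assay on microsomes from liver for inhibition of 3-hydroxy-3-methylglutaryl-coenzyme A reductase (Rattus norvegicus); a higher number here means a weaker inhibitor, a lower number a stronger inhibitor. Compound 1 `CC(C)c1c(C(=O)N(C)Cc2ccccc2)nn(-c2ccc(F)cc2)c1CC[C@@H](O)C[C@@H](O)CC(=O)O` gives 6.2 nM in this assay . Compound 3 `CC(C)c1c(C(=O)N2CCC[C@H](N3CCC4C=CC=CC4C3)C2)nn(-c2ccc(F)cc2)c1CC[C@@H](O)C[C@@H](O)CC(=O)O` gives 10 nM. Compound 2 `CC(C)c1c(C(=O)NCC2CCCCC2)nn(-c2ccc(F)cc2)c1OC[C@@H](O)C[C@@H](O)CC(=O)O` gives 17 nM, the highest of the three: its gap to compound 3 lies within the scatter, its gap to compound 1 lies beyond it. Compound 1 and compound 3 both carry a tertiary amide; compound 2 carries a secondary one, with the amide hydrogen.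

Compound 4 `CC(C)c1c(C(=O)N2CCC[C@H](c3ccccc3)C2)nn(-c2ccc(F)cc2)c1OC[C@@H](O)C[C@@H](O)CC(=O)O` is not yet measured. It differs from compound 2 by 3-phenylpiperidin-1-yl in place of (cyclohexylmethyl)amino on a carbonyl carbon, so the amide becomes tertiary while the rest of compound 2 is kept. Within the data shown here, no step between measured compounds isolates this change.

Because compound 1 gives 6.2 nM with a tertiary amide, a downward step is expected for compound 4, of a size around the edge of the scatter rather than clearly beyond it. The step of a 1.9-fold lower number from compound 2 to compound 4 (0.28 log units; within the scatter) is the expectation. Compound 4 is estimated at 9 nM, within 3 nM to 30 nM.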

Compound 4, half-maximal inhibitory concentration: 4.8 nM
Estimate against measurement, compound 4: 1.9-fold (0.27 log units) above; the measured number falls inside the stated range.
By their numbers in this assay, from the lowest: compounds 4, 1, 3 and 2 (each within the scatter of the next, the first and the last beyond it).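

On the carbonyl carbon, 3-phenylpiperidin-1-yl in place of (cyclohexylmethyl)amino gives a 3.5-fold lower number from compound 2 to compound 4 (0.55 log units; beyond the scatter) in this assay. Among these compounds, this is the first step that isolates a change at this place, and it shows that the amide hydrogen of compound 2 is not needed for a low number with this core. The change alters several things at once, removing the amide hydrogen, adding an aromatic ring and introducing a defined stereocentre, and no measurement available here accounts for the step.

The compounds shown do not separate the contribution of the phenyl ring from that of the tertiary amide. An unsubstituted piperidin-1-yl or a 4-phenylpiperidin-1-yl on the same carbonyl carbon would address that question, and the opposite stereoisomer of compound 4 would test the role of the stereocentre.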